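From 4-fluorobenzyl to 3,4-difluorobenzyl

The source may report more compounds than this note shows. Statements on the series, on what has been measured and on what is new or still open speak of the compounds shown alone.

Among the measured compounds shown here, in a functional assay, read by spectrophotometry, with a stated time of 30 min (on this read-out higher numbers stand for weaker inhibition and lower numbers for stronger inhibition), compound 1 `Cc1ccc(CN2CCC(CCNC(=O)/C=C/c3cc(C(C)(C)C)c(O)c(C(C)(C)C)c3)CC2)cc1` gives 60400 nM and compound 2 `CC(C)(C)c1cc(/C=C/C(=O)NCCC2CCN(Cc3ccc(F)cc3)CC2)cc(C(C)(C)C)c1O` gives 57500 nM as its value, so compound 2 stands within the usual scatter of its only measured neighbour. Compound 3 `CC(C)(C)c1cc(/C=C/C(=O)NCCC2CCN(Cc3ccc(F)c(F)c3)CC2)cc(C(C)(C)C)c1O` differs from compound 2 by one change fluoro in place of hydrogen on an aromatic carbon in which fluoro takes the place of hydrogen on an aromatic carbon, so 4-fluorobenzyl becomes 3,4-difluorobenzyl. For the measured compounds named here, one measured step bears on this, a 1.1-fold lower number from compound 1 to compound 2 (0.02 log units; within the scatter) with fluoro in place of methyl on an aromatic carbon, and it lies within the scatter. That single step involves a different swap, so it guides only loosely, and no step beyond the scatter is expected in this assay for the new change. The estimated step of a 1.0-fold lower number from compound 2 to compound 3 (0.02 log units; within the scatter) is accordingly a small one. Compound 3 is expected to give 55000 nM with an estimated range of 28000 nM to 110000 nM as its likely span.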

Compound 3, half-maximal inhibitory concentration: 65700 nM
Compound 3: middle estimate off by 1.2-fold (0.08 log units), on the low side; the range from low to high includes it.
By their numbers in this assay, from the lowest: compounds 2, 1 and 3 (each within the scatter of the next).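

In this assay, adding a second fluoro on an aromatic carbon, ortho to the fluoro group already there, turns 4-fluorobenzyl into 3,4-difluorobenzyl and gives a 1.1-fold higher number from compound 2 to compound 3 (0.06 log units; within the scatter). Among the compounds shown here, the earlier compounds showed only fluoro in place of methyl, so this is the first look at fluoro in place of hydrogen on this ring, and here too the step stays within the scatter. Putting 3,4-difluorophenyl in place of 4-methylphenyl gives a 1.1-fold higher number from compound 1 to compound 3 (0.04 log units; within the scatter), so all three compounds sit within the scatter of one another.

Still open, from the compounds shown here alone, is whether a methoxy group, an amine or a carboxylic acid on this ring would give a step beyond the scatter. Also open, going by these compounds, is whether a longer chain in the shared core would shift the number. No measurement shown explains these results.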